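A few compounds are considered here, and "the series" means these few. Any claim that something is new, unique, unknown or untested is made for them only; others in the source may bear on it.

Among the compounds with values here, compound 1 `CCCCCCCCCC(=O)OCC1CN(C(=O)c2cc(OC)c(OC)c(OC)c2)CCN1C(=O)c1cc(OC)c(OC)c(OC)c1` gives 2820 nM in a functional assay (Oryctolagus cuniculus) for inhibition of platelet-activating factor receptor (Cavia porcellus) (on this read-out lower numbers stand for stronger inhibition and higher numbers for weaker inhibition), the lowest of the two numbers measured; compound 2 `CCCCCCCCCCCCCCCCCC(=O)OCC1CN(C(=O)c2cc(OC)c(OC)c(OC)c2)CCN1C(=O)c1cc(OC)c(OC)c(OC)c1` gives 45000 nM, and the only measured step, a 16-fold higher number from compound 1 to compound 2 (1.20 log units; beyond the scatter), comes from lengthening the saturated chain. Compound 3 `CCC(C)(C)NC(=O)OCC1CN(C(=O)c2cc(OC)c(OC)c(OC)c2)CCN1C(=O)c1cc(OC)c(OC)c(OC)c1` differs from compound 1 by (1,1-dimethylpropyl)amino in place of nonyl on a carbonyl carbon. That measured step points the other way, from a longer chain to a worse number, so for compound 3 a shorter chain is expected to give a step of a 1.9-fold lower number from compound 1 to compound 3 (0.27 log units; within the scatter) in this assay, towards a somewhat lower number. Compound 3 is therefore estimated at 1500 nM, within 300 nM to 8000 nM.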

Compound 3, half-maximal inhibitory concentration: 320 nM
The estimate for compound 3 lay 4.7-fold (0.67 log units) above the measured number; measured number inside the range.
By their numbers in this assay, from the lowest: compound 3; then compound 1; then compound 2.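

Putting (1,1-dimethylpropyl)amino in place of nonyl on this carbonyl carbon gives an 8.8-fold lower number from compound 1 to compound 3 (0.95 log units; beyond the scatter) in this assay, a step beyond the scatter. The position therefore accepts more than a straight carbon chain, and a branched group with a nitrogen and a hydrogen-bond donor gives the better number here. No available evidence explains this gain. The step changes the branching and adds the nitrogen together, so it cannot show which of them matters. Nonylamino and hexylamino on the same carbonyl carbon remain open, as does any cyclic amine there.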